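Swapping 2-Fluorobenzyl for 4-Fluorophenyl on the Amide Nitrogen

The compounds below may be only part of what the source reports. "The series", "measured", "known", "first", "only" and "open" are said of these compounds alone.

Of the compounds shown here, three built on one shared core have been tested in a functional assay on Huh-7 cells (Homo sapiens) for inhibition, read by MTT assay, with a stated time of 48 h; on this read-out lower numbers stand for stronger inhibition and higher numbers for weaker inhibition. Compound 1 `COc1ccc2c(=O)c(/C=C/C(=O)NCc3cccc(F)c3)coc2c1` gives 10100 nM. Compound 2 `COc1ccc2c(=O)c(/C=C/C(=O)Nc3ccc(Cl)cc3)coc2c1` gives 37100 nM, and compound 3 `COc1ccc2c(=O)c(/C=C/C(=O)NCc3ccccc3F)coc2c1` gives 8450 nM. Compound 3 shows the lowest of these three numbers, yet its gap to compound 1 lies within the scatter, so those two cannot be ranked against each other; only against compound 2 does compound 3 stand clearly apart, the step being a 4.4-fold lower number from compound 2 to compound 3 (0.64 log units; beyond the scatter).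

Compound 4 `COc1ccc2c(=O)c(/C=C/C(=O)Nc3ccc(F)cc3)coc2c1` has not yet been measured. It differs from compound 3 in a single place: 4-fluorophenyl in place of 2-fluorobenzyl on an amide-type nitrogen. Among the compounds with values here, two measured steps bear on this change, as each exchanges a benzyl group on the amide-type nitrogen for a phenyl group on that same nitrogen, or the reverse: a 3.7-fold higher number from compound 1 to compound 2 (0.57 log units; beyond the scatter) and a 4.4-fold lower number from compound 2 to compound 3 (0.64 log units; beyond the scatter). Both point the same way, the phenyl group going with the higher number, that is, weaker inhibition. Within the data shown here, the change from compound 3 to compound 4 follows this pattern, and no compound among the three goes against it.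

Compound 4 is therefore expected to give a higher number than compound 3, an estimated step of a 3.6-fold higher number from compound 3 to compound 4 (0.55 log units; beyond the scatter). The estimate for compound 4 is 30000 nM, with a range from 12000 nM to 75000 nM.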

Compound 4, half-maximal inhibitory concentration: 33900 nM
The estimate for compound 4 lay 1.1-fold (0.05 log units) below the measured number, within the range that was stated.
By their numbers in this assay, from the lowest: compounds 3 and 1 (each within the scatter of the next); then compounds 4 and 2 (each within the scatter of the next).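

In this assay, the link between a phenyl group on the amide-type nitrogen and weaker inhibition now holds with fluoro on both sides of the exchange, with a 4.0-fold higher number from compound 3 to compound 4 (0.60 log units; beyond the scatter) and a 3.4-fold higher number from compound 1 to compound 4 (0.53 log units; beyond the scatter). The earlier benzyl-to-phenyl steps all involved the 4-chlorophenyl of compound 2, so chloro and fluoro changed along with the group, whereas these new steps keep the same halogen. Fluoro in place of chloro on the phenyl ring leaves no readable difference, with a 1.1-fold lower number from compound 2 to compound 4 (0.04 log units; within the scatter), and none of the four compounds goes against the pattern that both phenyl compounds give higher numbers than both benzyl compounds.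

Nothing shown explains why the phenyl compounds give the higher numbers. Still open, on these data alone, is whether the same pattern would hold for a 4-fluorobenzyl group, which would match the fluoro placement of compound 4, for a longer chain such as 2-phenylethyl on the nitrogen, or for a phenyl ring carrying an amine or a carboxylic acid.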